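Methylsulfonyl in Place of Methyl: an Expected Step

The compounds below may be only part of what the source reports. "The series", "measured", "known", "first", "only" and "open" are said of these compounds alone.

For the measured compounds named here, in an assay for inhibition of Tryptophan 2,3-dioxygenase (Homo sapiens), with stated times of 10 min and 60 min, tested at 100 uM (a lower number here means a weaker effect, a higher number a stronger effect of the compound at the concentration tested), compound 2 `Cc1ccc(CNc2cc(C(F)(F)F)cc3[nH]ncc23)c([N+](=O)O)c1` gives 92%, the higher of the two numbers known, whereas compound 1 `FC(F)(F)c1cc(NCc2cccc3sccc23)c2cn[nH]c2c1` gives 5%, a gap beyond the scatter. Compound 3 `CS(=O)(=O)c1ccc(CNc2cc(C(F)(F)F)cc3[nH]ncc23)c([N+](=O)O)c1` differs from compound 2 in one place: methylsulfonyl in place of methyl on an aromatic carbon. Going by the values given here, no measured pair shows this change, so its effect is unknown from the data; a downward step of moderate size is expected, a number 22 percentage points lower from compound 2 to compound 3 (beyond the scatter), since a value near the top leaves little room upward. Compound 3 is therefore estimated to give 70% in this assay, with a range from 30% to 95%.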

Compound 3, a percentage reported as inhibition, at one concentration (the size of the read-out at that concentration, not a potency): 98%
Beside the measured number, compound 3's estimate is 28 percentage points below it; the measured number lies above the stated range.
By their numbers in this assay, from the lowest: compound 1; then compounds 2 and 3 (each within the scatter of the next).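

Methylsulfonyl in place of methyl on this aromatic carbon, para to a large group, gives a number 6 percentage points higher from compound 2 to compound 3 (within the scatter) in this assay and so leaves the read-out unchanged. The position therefore accepts a group with more heavy atoms and with hydrogen-bond acceptors, which methyl lacks, without loss of effect. At this single concentration, compound 2 and compound 3 cannot be told apart. On these data alone, whether an amine or a carboxylic acid on the same carbon would hold the effect stays open, as does whether compound 2 and compound 3 would differ in the size of their effect at any other concentration. Nothing in the available data explains why this change leaves the effect in place.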